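Acyl group variation on the amide of compound 2

The source may report more compounds than this note shows. Statements on the series, on what has been measured and on what is new or still open speak of the compounds shown alone.

Measured so far in a functional assay (Sus scrofa) with sulfonylurea receptors; K-ATP channels (Homo sapiens) as the target; a lower number here means a smaller maximal response, a higher number a larger maximal response:

- compound 1, `CCC(=O)Nc1c(C(O)(C(F)(F)F)C(F)(F)F)ccc2ccccc12`, gives 96%
- compound 2, `O=C(Nc1c(C(O)(C(F)(F)F)C(F)(F)F)ccc2ccccc12)C1CC1`, gives 100%

Compound 2 carries the top figure of the two, yet the step of a number 4 percentage points higher from compound 1 to compound 2 (within the scatter) lies within the scatter, so compound 1 and compound 2 are not separated by this assay.

The next compound is compound 3, `COCC(=O)Nc1c(C(O)(C(F)(F)F)C(F)(F)F)ccc2ccccc12`. It differs from compound 2 by methoxymethyl in place of cyclopropyl on a carbonyl carbon. For the measured compounds named here, the only measured step that touches the same place is the one from compound 1 to compound 2, and a number 4 percentage points higher from compound 1 to compound 2 (within the scatter) was within the scatter. Going by the values given here, that step exchanged one carbon-only group for another; no measured step exchanges such a group for one holding an oxygen acceptor, so the effect of the acceptor is unknown here.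

On that basis the expectation for compound 3 is a step of a number 5 percentage points lower from compound 2 to compound 3 (within the scatter), not beyond the scatter, with a somewhat widened range to allow for the untested acceptor. Compound 3 is estimated to give 95% in this assay, between 80% and 105%.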

Compound 3, largest response reached (reported as efficacy), in percent of the reference or control that the assay uses: 93%
Compound 3: the middle estimate sits 2 percentage points above what was measured; the measured number falls inside the stated range.
By their numbers in this assay, from the lowest: compounds 3, 1 and 2 (each within the scatter of the next).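

In this assay, an oxygen acceptor on this acyl group yields no resolved change: methoxymethyl in place of cyclopropyl on the carbonyl carbon gives a number 7 percentage points lower from compound 2 to compound 3 (within the scatter), and methoxy in place of methyl on the saturated chain carbon bound to the carbonyl carbon gives a number 3 percentage points lower from compound 1 to compound 3 (within the scatter). The earlier pair compared only carbon-only groups, whereas these steps add a group with one hydrogen-bond acceptor, and the first also removes the three-membered ring, with neither step going beyond the scatter. Nothing measured here offers an explanation for these numbers, so the result remains a plain observation on the three compounds.

Still open, from the compounds shown here alone, is whether a markedly different group on this carbonyl carbon, such as a dimethylaminomethyl amine, a carboxylic acid or a longer chain such as n-butyl, would give a step beyond the scatter. Also open is whether an aromatic group such as phenyl at this place would separate from the three compounds shown, none of which can yet be placed apart from the others.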